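This account rests on a few compounds, and the source may have more. Where it says the series, first, only, none or still open, it means among the compounds named here.

Measured compounds:
- compound 1 `OC[C@@H]1C[C@H](CO)[C@@H]2C(c3ccc(F)cc3)=NO[C@H]12`: 31.1 ug/mL in a functional assay on A549 cells (Homo sapiens) for cytotoxicity, read by MTT assay, with a stated time of 48 h; on this read-out higher numbers stand for weaker inhibition and lower numbers for stronger inhibition
- compound 2 `OC[C@@H]1C[C@H](CO)[C@@H]2C(c3ccc4ccccc4c3)=NO[C@H]12`: > 50 ug/mL in this assay, a limit of the assay and not a number

For the measured compounds named here, compound 1 holds the only number given in this assay, where it gives 31.1 ug/mL. For compound 2 the assay gives only the limit (the limit of > 50 ug/mL in this assay, at which 1 of the 2 values shown sits), so no number stands beside it. Compound 3 `OC[C@@H]1C[C@H](CO)[C@@H]2C(c3ccc(Br)cc3)=NO[C@H]12` has not yet been measured in this assay. It differs from compound 1 in one place: bromo in place of fluoro on an aromatic carbon. Going by the values given here, no step between two measured compounds is available, so the size of the change that bromo brings in place of fluoro on this core cannot be read from the data. Compound 2 contributes only a limit and so no starting point. Because compound 1 gives 31.1 ug/mL, the expectation for compound 3 rests on compound 1 alone, and a step of a 1.1-fold lower number from compound 1 to compound 3 (0.05 log units; within the scatter) is expected, which lies within the scatter of the assay. Compound 3 is therefore estimated to give 28 ug/mL in this assay, with a range of 12 ug/mL to 50 ug/mL.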

Compound 3, half-maximal inhibitory concentration: > 50 ug/mL
Compound 3 ended at the assay's limit; the forecaster's own chance of this, stated with the estimate: 25%; middle value at least 1.7-fold (0.25 log units) away from the limit.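

For the compounds shown here, this position now has its only readable step: bromo in place of fluoro on an aromatic carbon, para to a large group, gives an at least 1.6-fold higher number from compound 1 to compound 3 (0.20 log units; that floor lies within the scatter) in this assay. Compound 3 gives > 50 ug/mL, which is a limit of the assay and not a number, so the step has a floor but no measured size, and that floor does not clear the usual scatter of the assay. The exchange of one halogen for another at this place therefore brought no sign of a lower number, and the series now gathers at the top of the measurable range, with only compound 1 holding a number: the limit of > 50 ug/mL in this assay, at which 2 of the 3 values shown sit.

The compounds shown leave open how large the step from fluoro to bromo really is, and whether the change in halogen matters at all beyond the scatter, since the result for compound 3 marks only where the assay stops. They also leave open what chloro, methoxy or an amine on the same aromatic carbon of the shared core would give in this assay.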